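The compounds below may be only part of what the source reports. "The series", "measured", "known", "first", "only" and "open" are said of these compounds alone.

Measured in a functional assay on HUVEC cells (Homo sapiens) for inhibition (a higher number here means a weaker inhibitor, a lower number a stronger inhibitor), so far:
- compound 1 `COc1cc(/C=C/C(=O)c2cccc(NC(=O)c3c(Cl)cccc3Cl)c2)ccc1O` gives 0.46 ug/mL 
- compound 2 `COc1cc(/C=C/C(=O)c2cccc(NC(=O)c3ccc(Cl)cc3)c2)ccc1O` gives 0.76 ug/mL 
- compound 3 `COc1cc(/C=C/C(=O)c2cccc(N)c2)ccc1O` gives 2.87 ug/mL 

Not yet measured: compound 4 `COc1cc(/C=C/C(=O)c2cccc(NC(=O)C(C)C)c2)ccc1O` 

Compound 3 at 2.87 ug/mL has the highest number of the three and is the weakest inhibitor among them. The next step puts isopropylcarbonyl in place of hydrogen on a nitrogen on an aromatic ring, (isopropylcarbonyl in place of hydrogen on a nitrogen on an aromatic ring), giving compound 4.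

Among the measured compounds shown here, two measured steps bear on this, both read in reverse: a 3.8-fold higher number from compound 2 to compound 3 (0.58 log units; beyond the scatter) and a 6.2-fold higher number from compound 1 to compound 3 (0.80 log units; beyond the scatter). Each replaces an acyl group on that nitrogen with hydrogen, and each number rises modestly. The step of a 1.7-fold higher number from compound 1 to compound 2 (0.22 log units; within the scatter) shows no separation between the two acylated compounds. For the measured compounds named here, both of those acyl groups carry a ring, whereas isopropylcarbonyl has none, so no measured compound covers this group directly. A modest fall in the number is therefore expected, probably smaller than the two measured steps, with the estimated step of a 2.4-fold lower number from compound 3 to compound 4 (0.38 log units; beyond the scatter) in this assay. Compound 4 is estimated at 1.2 ug/mL, with an expected range of 0.5 ug/mL to 3 ug/mL.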

Compound 4, half-maximal inhibitory concentration: 1.44 ug/mL
Compound 4: middle estimate off by 1.2-fold (0.08 log units), on the low side; low and high end bracket the measured number.
By their numbers in this assay, from the lowest: compounds 1, 2, 4 and 3 (each within the scatter of the next, the first and the last beyond it).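

In this assay, acylating the aromatic amine with a ring-free group gives a 2.0-fold lower number from compound 3 to compound 4 (0.30 log units; within the scatter), so isopropylcarbonyl on this nitrogen is not separated from hydrogen, unlike the two ring-bearing acyl groups. Among the compounds shown here, on the carbonyl carbon, isopropyl in place of 4-chlorophenyl gives a 1.9-fold higher number from compound 2 to compound 4 (0.28 log units; within the scatter), so these two groups are not separated either, while isopropyl in place of 2,6-dichlorophenyl gives a 3.1-fold higher number from compound 1 to compound 4 (0.50 log units; beyond the scatter) and is the only resolved step of the three. No supporting data bear on the reason for these steps.

Open, on these data alone, is whether the ring or its chlorine carries the separation from hydrogen, which a plain benzoyl or a cyclohexylcarbonyl group on the same nitrogen would address. Also open, as far as these compounds go, is how a longer chain or a carboxylic acid on that acyl group would read in this assay here.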